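Acrylonitrile amide series: pyrrolyl to chlorophenyl swap

This account rests on a few compounds, and the source may have more. Where it says the series, first, only, none or still open, it means among the compounds named here.

Measured compounds:
compound 1 `N#C/C(=C\c1ccc[nH]1)C(=O)NCc1ccc(Cl)c(Cl)c1`, > 50000 nM
compound 2 `COc1ccc(CNC(=O)/C(C#N)=C/c2cc(Br)co2)cc1`, 23000 nM

Compound 1 `N#C/C(=C\c1ccc[nH]1)C(=O)NCc1ccc(Cl)c(Cl)c1` is tested in a functional assay on SJ-G2 cells (Homo sapiens) for inhibition, read by MTT assay, with a stated time of 72 h; on this read-out higher numbers stand for weaker inhibition of growth and lower numbers for stronger inhibition of growth. For compound 1 the result is only a limit of the assay, > 50000 nM, as set out in the limit of > 50000 nM in this assay, at which 1 of the 2 values shown sits. Compound 2 `COc1ccc(CNC(=O)/C(C#N)=C/c2cc(Br)co2)cc1` gives 23000 nM in this assay. Among the measured compounds shown here, no step between measured compounds is available, so the two values show only that both sit at the weak end of the measured range.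

Compound 3 `N#C/C(=C\c1ccc(Cl)cc1)C(=O)NCc1ccc(Cl)c(Cl)c1` is not yet measured. It differs from compound 1 by 4-chlorophenyl in place of 1H-pyrrol-2-yl on a double-bonded chain carbon bound to a double-bonded chain carbon. For the measured compounds named here, with no measured step to lean on, the expected step from compound 1 to compound 3 in this assay, an at least 1.6-fold lower number from compound 1 to compound 3 (0.22 log units; that floor lies within the scatter), is small and of uncertain direction. Compound 3 is therefore estimated at 30000 nM, with a range from 8000 nM to 100000 nM.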

Compound 3, concentration for 50% growth inhibition: 30000 nM
Compound 3: the middle estimate sits on the measured number at the digits printed; the measured number falls inside the stated range.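

In this assay, among the compounds shown here, this change gives an at least 1.6-fold lower number from compound 1 to compound 3 (0.22 log units; that floor lies within the scatter) as the first step between measured compounds. On the core of compound 1, 4-chlorophenyl with 0 hydrogen-bond donors in place of 1H-pyrrol-2-yl with 1 hydrogen-bond donor brings a measured number into reach, and compound 3 gives 30000 nM. Compound 1 gives > 50000 nM, which is a limit of the assay and not a number, so the step is only a floor: the limit of > 50000 nM in this assay, at which 1 of the 3 values shown sits.

As far as these compounds go, whether the chlorine or the six-membered ring goes with this step remains open, and plain phenyl or 4-methoxyphenyl at this place would separate the two. From the compounds shown here alone, how far the step extends beyond its floor is also open, and compound 2 differs from compound 1 and compound 3 in more than one place, so it offers no comparison here.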